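The source may report more compounds than this note shows. Statements on the series, on what has been measured and on what is new or still open speak of the compounds shown alone.

Working notes on the series. In an assay on isolated protein for inhibition of Dipeptidyl peptidase 9 (Homo sapiens), read by fluorescence, with stated times of 15 min and 20 min (on this read-out lower numbers stand for stronger inhibition and higher numbers for weaker inhibition), compound 1 `CC#CCn1c(N2CCC[C@@H](N)C2)cc(=O)n(Cc2ccc(F)c(C(=O)OC)c2)c1=O` gives only a limit, > 100 nM, and no number. Compound 2 `CC#CCn1c(N2CCC[C@@H](N)C2)cc(=O)n(Cc2cccc(C(=O)OC)c2F)c1=O` likewise returns only a limit in this assay, > 100 nM. Among the compounds with values here, compound 1 therefore sits at the limit of > 100 nM in this assay, at which 2 of the 2 values shown sit, with no measured step to set a scale. Compound 3 `CC#CCn1c(N2CCC[C@@H](N)C2)cc(=O)n(Cc2ccc(F)c(C(=O)O)c2)c1=O` differs from compound 1 by hydrogen in place of methyl on an oxygen next to a carbonyl group. With no measured step shown, the expected step that the limit leaves unreadable from compound 1 to compound 3 is set to none beyond the scatter, and the result is most likely to be another limit. Compound 3 is accordingly expected near 300 nM, within 100 nM to 3000 nM.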

Compound 3, half-maximal inhibitory concentration: > 100 nM
Compound 3: no number, only a limit; the forecaster's own chance of this, stated with the estimate: 75%; the middle value does not contradict the limit.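

Compound 3 gives only a limit in this assay, > 100 nM. Compound 1 is also only a limit, so no step between compound 1 and compound 3 can be read: the limit of > 100 nM in this assay, at which 3 of the 3 values shown sit.

The compounds shown leave open how far each true value lies from this limit, and whether replacing methoxycarbonyl with carboxy changes inhibition at all.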